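This account rests on a few compounds, and the source may have more. Where it says the series, first, only, none or still open, it means among the compounds named here.

The study centers on three compounds that share one core and differ in the group carried on the amide-type carbonyl. Compound 1 `O=C(Nc1nc2ccc(Oc3ccc(F)c(NCc4cccc(C(F)(F)F)c4)c3)cc2s1)C1CC1` was included, but in an assay for binding affinity to receptor-interacting serine/threonine-protein kinase 3 (Homo sapiens), read by KINOMEscan and polymerase chain reaction, with a stated time of 1 h (on this read-out lower numbers stand for tighter binding and higher numbers for weaker binding), the entry for compound 1 reads "not determined" (no result reported), so no result was reported for it. Within the data shown here, compound 2 `O=C(CCc1cccc(C(F)(F)F)c1)Nc1cc(Oc2ccc3nc(NC(=O)C4CC4)sc3c2)ccc1F` is the one compound with a number: in this assay compound 2 gives 790 nM, so it is the only reference point here, with nothing to compare it against.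

Compound 3 `COc1cccc(NC(=O)Nc2cc(Oc3ccc4nc(NC(=O)C5CC5)sc4c3)ccc2F)c1` is the compound still to be measured. It differs from compound 2 in one place ((3-methoxyphenyl)amino in place of 2-(3-(trifluoromethyl)phenyl)ethyl on a carbonyl carbon), so the carbonyl that carried a 2-(3-(trifluoromethyl)phenyl)ethyl group now carries a (3-methoxyphenyl)amino group, which brings one hydrogen-bond donor and one hydrogen-bond acceptor where there were none.

Among the measured compounds shown here, no step between two measured compounds is available to calibrate this change. With only compound 2 at 790 nM to go on, the expected step of a 1.6-fold lower number from compound 2 to compound 3 (0.20 log units; within the scatter) is a modest shift toward tighter binding, small enough that it may not clear the usual scatter. Compound 3 is therefore expected to come in at about 500 nM, within a range from 100 nM to 3000 nM.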

Compound 3, dissociation constant: 69 nM
Estimate against measurement, compound 3: 7.2-fold (0.86 log units) above, outside the stated range (below it).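

In this assay, (3-methoxyphenyl)amino in place of 2-(3-(trifluoromethyl)phenyl)ethyl on a carbonyl carbon gives an 11-fold lower number from compound 2 to compound 3 (1.06 log units; beyond the scatter), which shows that the group on this carbonyl, whose other neighbour is an amide-type nitrogen, can shift binding beyond the scatter, and that this change moves it toward tighter binding. Among these compounds, the step combines several differences, since the entering group brings a hydrogen-bond donor and a hydrogen-bond acceptor while the trifluoromethyl group and the ethyl chain leave, so this one comparison cannot assign the shift to any single part of the change; compound 1 has no reported result, so no step involving it can be read. Nothing available here bears on why the number falls so far.

Going by these compounds, it remains open whether the nitrogen attached to the carbonyl, the methoxy group or both carry the shift, which an unsubstituted phenylamino group or a 3-(trifluoromethyl)phenylamino group on the same carbonyl could help separate. On these data alone, it is also open how far the trend extends to other groups at this place, such as a longer chain between the carbonyl and the ring or a carboxylic acid on the ring.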